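Notes on the step to compound 3

This account rests on a few compounds, and the source may have more. Where it says the series, first, only, none or still open, it means among the compounds named here.

- compound 1 `Cc1ccccc1NNC(=O)c1ccccc1NS(=O)(=O)c1cnc(O)nc1O` gives > 20000 nM as a limit
- compound 2 `Cc1cccc(NNC(=O)c2ccccc2NS(=O)(=O)c2cnc(O)nc2O)c1` gives > 20000 nM as a limit

In a functional assay on MDA-MB-231 cells (Homo sapiens) for antiproliferative activity, read by MTT assay, with a stated time of 24 h (on this read-out lower numbers stand for stronger inhibition and higher numbers for weaker inhibition), compound 2 stands at > 20000 nM as a limit, not a number. So far the series offers only the limit of > 20000 nM in this assay, at which 2 of the 2 values shown sit, and no measured number. Compound 3 `O=C(NNc1ccccc1Cl)c1ccccc1NS(=O)(=O)c1cnc(O)nc1O` has 2-chlorophenyl in place of 3-methylphenyl on an amine nitrogen and keeps the rest of the structure. Among the compounds with values here, the only measured step bearing on this is a step that the two limits leave unreadable from compound 1 to compound 2 and it gives no size to carry over, so no shift in either direction beyond the usual scatter is expected in this assay for this change. The estimated move is a step that the limit leaves unreadable from compound 2 to compound 3 and it may stay hidden behind a limit. Compound 3 is expected at 25000 nM with an estimated range from 10000 nM to 50000 nM and is most likely to be reported as a limit again.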

Compound 3, half-maximal inhibitory concentration: 18900 nM
The estimate for compound 3 lay 1.3-fold (0.12 log units) above the measured number, and the stated range covers the measured number.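

With 2-chlorophenyl on the amine nitrogen, compound 3 is the only compound shown that gives a number rather than a limit in this assay. The change reads as an at least 1.0-fold lower number from compound 2 to compound 3 (0.02 log units; that floor lies within the scatter), and chloro in place of methyl on an aromatic carbon reads as an at least 1.0-fold lower number from compound 1 to compound 3 (0.02 log units; that floor lies within the scatter). Both steps remain floors because the earlier compounds rest on a limit: the limit of > 20000 nM in this assay, at which 2 of the 3 values shown sit.

As far as these compounds go, how far compound 1 and compound 2 actually lie from compound 3 remains open. So does how a carboxylic acid or an amine on this phenyl ring would read.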